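From pyrrolidin-1-yl to 1H-pyrazol-1-yl on a shared core

The compounds below may be only part of what the source reports. "The series", "measured", "known", "first", "only" and "open" are said of these compounds alone.

In a functional assay on SK-MEL-2 cells (Homo sapiens) for cytotoxicity (on this read-out higher numbers stand for weaker inhibition and lower numbers for stronger inhibition), compound 1 `Cc1nn(C)c(-n2ccc3ccccc32)c1/C=N/OCc1ccc(C(=O)OC(C)(C)C)cc1` gives 26.5 ug/mL and compound 2 `Cc1nn(C)c(N2CCCC2)c1/C=N/OCc1ccc(C(=O)OC(C)(C)C)cc1` gives 14.4 ug/mL. Only these two values are available, and they lie within the usual scatter of each other, so compound 2 cannot be ranked with any confidence. Compound 3 `Cc1nn(C)c(-n2cccn2)c1/C=N/OCc1ccc(C(=O)OC(C)(C)C)cc1` keeps the shared core and changes one group: 1H-pyrazol-1-yl in place of pyrrolidin-1-yl on an aromatic carbon. Among the measured compounds shown here, one measured step bears on this change, since it also exchanges the group on that aromatic carbon: a 1.8-fold lower number from compound 1 to compound 2 (0.26 log units; within the scatter). That single step is small, and it offers no firm basis for predicting a large shift, so no change beyond the scatter is expected. The expected step is a 1.4-fold higher number from compound 2 to compound 3 (0.14 log units; within the scatter). In this assay, the estimate for compound 3 is 20 ug/mL, with an expected range from 9 ug/mL to 45 ug/mL.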

Compound 3, half-maximal inhibitory concentration: 28.8 ug/mL
The estimate for compound 3 lay 1.4-fold (0.16 log units) below the measured number; the range from low to high includes it.
By their numbers in this assay, from the lowest: compounds 2, 1 and 3 (each within the scatter of the next).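

In this assay, the exchange of pyrrolidin-1-yl for 1H-pyrazol-1-yl gives a 2.0-fold higher number from compound 2 to compound 3 (0.30 log units; within the scatter), and the exchange of 1H-indol-1-yl for 1H-pyrazol-1-yl gives a 1.1-fold higher number from compound 1 to compound 3 (0.04 log units; within the scatter). With a third group on this aromatic carbon, the picture now extends beyond the first pair: a five-membered non-aromatic ring and a five-membered aromatic ring with 2 hetero atoms give values that this assay cannot tell apart, and the same holds for 1H-indol-1-yl. Nothing measured on these compounds offers an explanation for this result.

From the compounds shown here alone, all three groups at this position are rings attached through nitrogen, so it remains open whether an open-chain amine such as dimethylamino would give a step beyond the scatter. The tert-butyl ester is also shared by all three compounds, which leaves open what a free carboxylic acid in its place would do.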